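Chloro on the pyridyl of a D4 agonist series

The source may report more compounds than this note shows. Statements on the series, on what has been measured and on what is new or still open speak of the compounds shown alone.

Measured compounds:
compound 1 `CCc1cccc(NC(=O)CN2CCN(c3ccccn3)CC2)c1` — 133 nM
compound 2 `O=C(CN1CCN(c2ccccn2)CC1)Nc1cccnc1` — 2660 nM
compound 3 `Cc1ccc(C2CCN(CC(=O)Nc3cccc(C)c3)CC2)cc1` — "not active" (no number reported)

In an assay on cells for agonist activity at D(4) dopamine receptor (Homo sapiens), read by luminescence and beta-arrestin recruitment, with a stated time of 90 min (on this read-out lower numbers stand for an effect already at smaller amounts and higher numbers for an effect only at larger amounts of compound), compound 1 gives 133 nM and stands lowest of the two numbers recorded. The nearest entry is compound 2, for which the step of a 20-fold higher number from compound 1 to compound 2 (1.30 log units; beyond the scatter) is large, and compound 3 is reported without a number as not active. Compound 4 `CCc1cccc(NC(=O)CN2CCN(c3ccc(Cl)cn3)CC2)c1` is the next step from compound 1: chloro in place of hydrogen on an aromatic carbon, that is, pyridin-2-yl becomes 5-chloropyridin-2-yl. Among the measured compounds shown here, none of the measured steps touches this part of the molecule; the one step known, from compound 1 to compound 2, alters the amide-type nitrogen substituent and so says nothing about the pyridyl ring. For the measured compounds named here, with no bearing step available, a change in this assay beyond the scatter is not expected in either direction for compound 4, and a 1.3-fold lower number from compound 1 to compound 4 (0.12 log units; within the scatter) is the estimated step. Compound 4 is therefore expected at about 100 nM, within a range of 30 nM to 400 nM.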

Compound 4, half-maximal effective concentration: "not active" (no number reported)
Nothing numeric was reported for compound 4; the estimate stays without a comparison.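

Among the compounds shown here, compound 4 is reported as not active with no number, and no step from compound 1 to compound 4 can be read. Nothing measured here bears on this result. The compounds shown leave open how other groups at this place on the pyridyl ring would read out.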